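The source may hold more compounds than are shown below. What is called first, only, known or untested is meant among the compounds shown, and "the series" means these compounds.

Compound 1 `CCN(CC)CCn1c(N)c(-c2nc3ccccc3n2C)c2nc(C#N)c(C#N)nc21`: > 50000 nM
Compound 2 `CN(C)CCCn1c(N)c(-c2nc3ccccc3n2C)c2nc(C#N)c(C#N)nc21`: 4320 nM
Compound 3 `CCN(CC)CCCn1c(N)c(-c2nc3ccccc3n2C)c2nc(C#N)c(C#N)nc21`: 12400 nM

In a functional assay on HeLa cells (Homo sapiens) for antiproliferative activity, read by MTT assay, with a stated time of 48 h (on this read-out higher numbers stand for weaker inhibition and lower numbers for stronger inhibition), compound 1 gives > 50000 nM, which is a limit rather than a number (the limit of > 50000 nM in this assay, at which 1 of the 3 values shown sits). In this assay compound 2 gives 4320 nM and compound 3 gives 12400 nM. Compound 3 differs from compound 1 by (diethylamino)methyl in place of diethylamino on a saturated chain carbon, two bonds along the chain from an aromatic nitrogen, a change that gave an at least 4.0-fold lower number from compound 1 to compound 3 (0.60 log units; beyond the scatter). Compound 2 differs from compound 1 by (dimethylamino)methyl in place of diethylamino on a saturated chain carbon, two bonds along the chain from an aromatic nitrogen, which gave an at least 11-fold lower number from compound 1 to compound 2 (1.06 log units; beyond the scatter). Between the two measured chains there is a 2.9-fold higher number from compound 2 to compound 3 (0.46 log units; beyond the scatter).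

Compound 4 `CN(C)CCCCn1c(N)c(-c2nc3ccccc3n2C)c2nc(C#N)c(C#N)nc21` is not yet measured. It differs from compound 3 by (dimethylamino)methyl in place of diethylamino on a saturated chain carbon, three bonds along the chain from an aromatic nitrogen. This is the same kind of change as that from compound 1 to compound 2, but here the place is three bonds along the chain from the aromatic nitrogen rather than two. For compound 4 the expected step is a 2.5-fold lower number from compound 3 to compound 4 (0.39 log units; beyond the scatter), resting on an at least 11-fold lower number from compound 1 to compound 2 (1.06 log units; beyond the scatter) being large while a 2.9-fold higher number from compound 2 to compound 3 (0.46 log units; beyond the scatter) was modest. Compound 4 is estimated at 5000 nM, between 1500 nM and 15000 nM.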

Compound 4, half-maximal inhibitory concentration: 460 nM
Beside the measured number, compound 4's estimate is 11-fold (1.04 log units) above it; the measured number lies below the stated range.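

In this assay there is a 27-fold lower number from compound 3 to compound 4 (1.43 log units; beyond the scatter), alongside a 9.4-fold lower number from compound 2 to compound 4 (0.97 log units; beyond the scatter) and an at least 100-fold lower number from compound 1 to compound 4 (2.03 log units; beyond the scatter). The same change thus lowered the number on both cores, but only these two pairs carry it, and whether its size is the same on each cannot be read: the same change on two cores in this assay, an at least 11-fold lower number (1.06 log units; beyond the scatter) from compound 1 to compound 2 and a 27-fold lower number (1.43 log units; beyond the scatter) from compound 3 to compound 4; the limit leaves it open whether they differ. Compound 1 stands at a limit and not at a number: the limit of > 50000 nM in this assay, at which 1 of the 4 values shown sits.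

The compounds shown leave open how 4-(diethylamino)butyl would compare with 4-(dimethylamino)butyl on the same core. They also leave open whether a longer chain would lower the number further, and whether a cyclic amine such as pyrrolidine or morpholine in place of dimethylamino would give a similar value.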